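Swapping pyridin-4-yl for thiophen-2-yl on compound 1

The source may hold more compounds than are shown below. What is called first, only, known or untested is meant among the compounds shown, and "the series" means these compounds.

Going by the values given here, in a functional assay on CWR22R cells (Homo sapiens) for antiproliferative activity, read by CCK-8 assay, with a stated time of 6 days (a lower number here means a stronger inhibitor, a higher number a weaker inhibitor), compound 1 (`CCN(c1ccc(C#N)c(Cl)c1)c1cc(-c2ccncc2)ccc1C`) gives 1030 nM as the only number available, so it cannot yet be ranked against anything. Compound 2 (`CCN(c1cccc(-c2ccccc2)c1)c1ccc(C#N)c(Cl)c1`) stands at "not determined" (no result reported) and compound 3 (`Cc1noc(C)c1-c1cccc(Oc2ccc(C#N)c(C(F)(F)F)c2)c1`) at "not determined" (no result reported) and so neither offers a comparison. Compound 4 (`CCN(c1ccc(C#N)c(Cl)c1)c1cc(-c2cccs2)ccc1C`) keeps the core of compound 1 but carries thiophen-2-yl in place of pyridin-4-yl on an aromatic carbon, so a five-membered aromatic ring replaces a six-membered one. Among the compounds with values here, no measured step exists to go by, so the expected step (a 1.3-fold lower number from compound 1 to compound 4 (0.11 log units; within the scatter)) in this assay is small, not beyond the scatter of repeat measurements, and no direction is favoured. Compound 4 is estimated at 800 nM with 250 nM to 2500 nM as the expected range.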

Compound 4, half-maximal inhibitory concentration: 22000 nM
The estimate for compound 4 lay 28-fold (1.44 log units) below the measured number, outside the stated range (above it).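

In this assay, thiophen-2-yl in place of pyridin-4-yl gives a 21-fold higher number from compound 1 to compound 4 (1.33 log units; beyond the scatter), the first sign that the choice of aromatic ring at this position, para to a methyl group, matters. Both rings count one hetero atom and one hydrogen-bond acceptor, so these counts do not separate them; ring size and the hetero atom, nitrogen or sulfur, do differ. No measurement here accounts for the large step.

On these data alone, it remains open whether ring size or the hetero atom drives the step. Pyridin-3-yl or furan-2-yl at this position on the core of compound 1 would help to tell these apart.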